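A few compounds are considered here, and "the series" means these few. Any claim that something is new, unique, unknown or untested is made for them only; others in the source may bear on it.

Measured compounds:
compound 1 `COc1cc(Cl)cc(-c2nn(-c3cccc(NC(=O)c4ccc(Cl)c(Cl)c4)c3)cc2-c2ccncc2)c1`, which gives 63.6% in a functional assay on Hs-578T cells (Homo sapiens) for inhibition, read by sulforhodamine B assay, with a stated time of 48 h, tested at 10 uM; on this read-out higher numbers stand for a weaker effect at the one concentration tested and lower numbers for a stronger effect
compound 2 `O=C(Nc1cccc(-n2cc(-c3ccncc3)c(-c3cc(O)cc(Cl)c3)n2)c1)Nc1ccc(Cl)c(C(F)(F)F)c1`, which gives 21.7% in this assay

Of the two numbers in this assay, compound 2 holds the lowest, and its nearest neighbour, compound 1, sits a good deal higher, a gap that lies beyond the usual scatter of this read-out. Going by the values given here, no pair of measured compounds differs in only one place, so the data offer no step of known size against which a single change could be weighed.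

Compound 3 `O=C(Nc1cccc(-n2cc(-c3ccncc3)c(-c3cc(O)cc(Cl)c3)n2)c1)Nc1ccc(Cl)c(Cl)c1` departs from compound 2 in one place: chloro in place of trifluoromethyl on an aromatic carbon. The exchange touches only an aromatic carbon that is ortho to a chloro group and meta to a large group, and nothing about the rest of the molecule moves. Among the compounds with values here, with no measured step to lean on, the account can only look at the smallness of the change. In this assay the expected step is a number 5.3 percentage points higher from compound 2 to compound 3 (within the scatter), small enough to stay within the scatter, if anything leaning towards a slightly higher number. Compound 3 is accordingly estimated at 27%, with a range from 12% to 48%.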

Compound 3, a percentage reported as activity, at one concentration (the size of the read-out at that concentration, not a potency): -6.42%
Estimate against measurement, compound 3: 33.4 percentage points above; the whole stated range lies above it.
By their numbers in this assay, from the lowest: compound 3; then compound 2; then compound 1.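

In this assay, going by these compounds alone, chloro in place of trifluoromethyl on this aromatic carbon gives a number 28.1 percentage points lower from compound 2 to compound 3 (beyond the scatter), the first single change in these compounds whose size can be read. The position is therefore not indifferent to what it carries: the 3,4-dichlorophenyl of compound 3, at -6.42%, has the stronger effect at the one concentration tested, compared with the 4-chloro-3-(trifluoromethyl)phenyl of compound 2, at 21.7%. Nothing measured on these compounds speaks to why this exchange moves the number as it does.

This single pair cannot show whether the step would hold on another part of the molecule, or whether a bromo, methyl, methoxy or nitrile group on the same carbon would give a number nearer that of compound 3 or that of compound 2. It also leaves open whether the effect seen at this one concentration in this assay would carry over to a full concentration series or to other cell lines.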